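Furan-2-yl in place of 4-methoxyphenyl on compound 2

This account rests on a few compounds, and the source may have more. Where it says the series, first, only, none or still open, it means among the compounds named here.

Measured so far in a functional assay on THP-1 cells (Homo sapiens) for inhibition, read by sulforhodamine B assay, with a stated time of 48 h, tested at 50 uM (a lower number here means less inhibition of growth, a higher number more inhibition of growth at the concentration tested), as follows
- compound 1 `COc1cc(/C=C/C(=O)/C=C/c2cccc3ccccc23)ccc1OCc1cn(CCCCOc2cc(=O)oc3ccccc23)nn1` gives 54%
- compound 2 `COc1ccc(/C=C/C(=O)/C=C/c2ccc(OCc3cn(CCCCCOc4cc(=O)oc5ccccc45)nn3)c(OC)c2)cc1` gives 39%
- compound 3 `COc1ccc(/C=C/C(=O)/C=C/c2ccc(OCc3cn(CCOc4cc(=O)oc5ccccc45)nn3)c(OC)c2)cc1OC` gives 90%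

Compound 2 holds the lowest of the three numbers. Compound 1 is the nearest, and compound 3 the furthest, with both lying higher beyond the scatter. These three compounds differ from one another in more than one place, so no measured single change is available to size the next step.

Compound 4 `COc1cc(/C=C/C(=O)/C=C/c2ccco2)ccc1OCc1cn(CCCCCOc2cc(=O)oc3ccccc23)nn1` has not yet been measured. It carries furan-2-yl in place of 4-methoxyphenyl on a double-bonded chain carbon bound to a double-bonded chain carbon, and the counted change is furan-2-yl in place of 4-methoxyphenyl on a double-bonded chain carbon bound to a double-bonded chain carbon with the rest of compound 2 kept.

The series gives no direct guide to this exchange, so only a modest change is expected in this assay, with no clear move beyond the scatter. For the measured compounds named here, the expectation leans slightly upward because compound 2 at 39% is the lowest value so far. The expected size is a number 6 percentage points higher from compound 2 to compound 4 (within the scatter) in this assay as estimated here. Compound 4 is expected at 45% in this assay with an estimated range from 25% to 70% for this compound.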

Compound 4, percent growth inhibition at one concentration: 39%
Compound 4: the middle estimate sits 6 percentage points above what was measured, and the stated range covers the measured number.
By their numbers in this assay, from the lowest: compounds 2 and 4 (each within the scatter of the next); then compound 1; then compound 3.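

In this assay, furan-2-yl in place of 4-methoxyphenyl on a double-bonded chain carbon bound to a double-bonded chain carbon gives no change at the digits printed from compound 2 to compound 4 (within the scatter). For the compounds shown here, this is the first single-place comparison, and it shows that at this position a six-membered aromatic ring of carbon only can give way to a five-membered aromatic ring with 1 hetero atom without a change that the read-out at this one concentration can separate from scatter. No measurement is at hand that explains why the two groups read alike.

Going by these compounds alone, whether this position stays equally flat for a different kind of group, such as a 4-(dimethylamino)phenyl or a pyridin-3-yl group, remains open, as does whether furan-2-yl reads the same on a shorter chain than the one in compound 4. Compound 3, at 90%, differs from compound 2 in more than one place, so the series does not yet assign that higher number to any single part of the structure.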